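Aryl sulfone series: swapping the styryl aryl of compound 1

This account rests on a few compounds, and the source may have more. Where it says the series, first, only, none or still open, it means among the compounds named here.

Compound 1 `O=C(/C(=C\c1ccc(F)c([N+](=O)[O-])c1)S(=O)(=O)c1ccc(Br)cc1)c1ccc(Br)cc1` is the weakest grower-inhibitor of the three measured here. In a functional assay on DU-145 cells (Homo sapiens) for inhibition, read by trypan blue exclusion, with a stated time of 96 h (a higher number here means a weaker inhibitor of growth, a lower number a stronger inhibitor of growth), compound 1 gives 25000 nM, the highest of the three numbers. Compound 2 `O=C(/C(=C\c1ccc(Cl)cc1)Sc1ccc(Br)cc1)c1ccc(Br)cc1` gives 1000 nM in this assay, and compound 3 `CCOc1ccc(/C=C(\C(=O)c2ccc(Cl)cc2)S(=O)(=O)c2ccc(C)cc2)cc1OC` gives 1000 nM; both stand a long way below compound 1, beyond the scatter, and the two of them lie within the scatter of each other, so no order between compound 2 and compound 3 is claimed. Within the data shown here, no single-point step between measured compounds is available, so the change to compound 4 is read only against these three values.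

Compound 4 `COc1ccc(/C=C(\C(=O)c2ccc(Br)cc2)S(=O)(=O)c2ccc(Br)cc2)c(OC)c1` differs from compound 1 as follows: 2,4-dimethoxyphenyl in place of 4-fluoro-3-nitrophenyl on a double-bonded chain carbon bound to a double-bonded chain carbon. The shared core otherwise stays as in compound 1. Because compound 3 reaches 1000 nM on the same core arrangement, a step toward lower numbers is expected from compound 1 to compound 4, well beyond the scatter. The expected step of a 17-fold lower number from compound 1 to compound 4 (1.22 log units; beyond the scatter) points toward stronger growth inhibition. Compound 4 is estimated at 1500 nM in this assay. Its expected range runs from 400 nM to 6000 nM.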

Compound 4, concentration for 50% growth inhibition: 8000 nM
The estimate for compound 4 lay 5.3-fold (0.73 log units) below the measured number, and the stated range ends below it.
By their numbers in this assay, from the lowest: compounds 2 and 3 (each within the scatter of the next); then compound 4; then compound 1.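

In this assay, 2,4-dimethoxyphenyl in place of 4-fluoro-3-nitrophenyl gives a 3.1-fold lower number from compound 1 to compound 4 (0.49 log units; beyond the scatter) with the rest of the shared core unchanged, so the aryl group on a double-bonded chain carbon bound to a double-bonded chain carbon does affect the read-out, though this step is modest. The step arises with the heavy-atom and hydrogen-bond acceptor counts of the two groups unchanged, so those counts alone do not set the value in this pair. Nothing measured here accounts for the step.

Still open, from the compounds shown here alone, is which part of the swap carries the step: loss of the nitro group, loss of the fluorine, or gain of the two methoxy groups. Also open, going by these compounds, is how an aryl group bearing an amine or a carboxylic acid at this place would read in this assay.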